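The source may hold more compounds than are shown below. What is called first, only, known or untested is meant among the compounds shown, and "the series" means these compounds.

Measured so far in a functional assay on G-361 cells (Homo sapiens) for antiproliferative activity, with a stated time of 72 h; on this read-out lower numbers stand for stronger inhibition and higher numbers for weaker inhibition:
- compound 1 `OC[C@H]1O[C@@H](n2cnc3c(NCc4ccc(Cl)c(Cl)c4)ncnc32)[C@H](O)[C@@H]1O`, which gives 145000 nM
- compound 2 `COc1cc(CNc2ncnc3c2ncn3[C@@H]2O[C@H](CO)[C@@H](O)[C@H]2O)cc(OC)c1O`, which gives > 166000 nM

The value for compound 2 is a limit of the assay, not a number. Among the measured compounds shown here, compound 1 is therefore the only compound of the pair with a numerical result in this assay; the other result sits at the limit, as the limit of > 166000 nM in this assay, at which 1 of the 2 values shown sits, records. For the measured compounds named here, no step between two measured compounds is available here, so the effect of any single structural change remains unknown from the data.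

Compound 3 `OC[C@H]1O[C@@H](n2cnc3c(NCc4ccccc4OC(F)F)ncnc32)[C@H](O)[C@@H]1O` is unmeasured. It differs from compound 1 in one place: 2-(difluoromethoxy)phenyl in place of 3,4-dichlorophenyl on a saturated chain carbon bound to a nitrogen on an aromatic ring. Given only the weak activity of compound 1 at 145000 nM, no shift beyond the usual scatter is expected from compound 1 to compound 3, with the direction undetermined.

Compound 3 is estimated at 140000 nM, within a range of 45000 nM to 450000 nM, an expected step of a 1.0-fold lower number from compound 1 to compound 3 (0.02 log units; within the scatter).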

Compound 3, half-maximal inhibitory concentration: > 166000 nM
Compound 3 ended at the assay's limit; the forecaster's own chance of this, stated with the estimate: 45%; at least 1.1-fold (0.07 log units) between middle value and limit.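

In this assay, among the compounds shown here, the replacement of 3,4-dichlorophenyl by 2-(difluoromethoxy)phenyl on a saturated chain carbon bound to a nitrogen on an aromatic ring gives the first readable step: an at least 1.1-fold higher number from compound 1 to compound 3 (0.05 log units; that floor lies within the scatter). Compound 3 gives > 166000 nM, which is a limit of the assay and not a number, so the step has a floor and no measured size. For the compounds shown here, this change does not give a second numerical result, and compound 1 remains the only compound with one, while the limit now recurs: the limit of > 166000 nM in this assay, at which 2 of the 3 values shown sit.

Going by these compounds, whether the true step from this change exceeds the usual scatter remains open. Also open, on these data alone, is how an amine or a carboxylic acid in place of 3,4-dichlorophenyl, or a longer chain at the same place, would read out in this assay.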